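A few compounds are considered here, and "the series" means these few. Any claim that something is new, unique, unknown or untested is made for them only; others in the source may bear on it.

Working notes on the series. Three formyl compounds on a shared core have numbers in a functional assay on MCF7 cells (Homo sapiens) for antiproliferative activity, with a stated time of 5 days; a lower number here means a stronger inhibitor, a higher number a weaker inhibitor: compound 1 (`CCCCc1ccc2[nH]c(-c3ccc(OC)cc3)c(C=O)c2c1`) gives 22 nM, compound 2 (`CCCCc1ccc2[nH]c(-c3ccc(C(F)(F)F)cc3)c(C=O)c2c1`) gives 66 nM and compound 3 (`CCCCc1ccc2[nH]c(-c3ccc(CC)cc3)c(C=O)c2c1`) gives 58 nM. Compound 2 stands at the upper end of this small set, level with compound 3, with a 1.1-fold lower number from compound 2 to compound 3 (0.06 log units; within the scatter). The gap to compound 1 is real: a 3.0-fold higher number from compound 1 to compound 2 (0.48 log units; beyond the scatter), and likewise a 2.6-fold higher number from compound 1 to compound 3 (0.42 log units; beyond the scatter).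

Compound 4 (`CCCCc1ccc2[nH]c(-c3ccc(C(F)(F)F)cc3)c(/C=N/NC(=O)c3cccnc3)c2c1`) keeps the trifluoromethyl of compound 2 and loses the formyl: a group of 11 heavy atoms (7 carbon, 3 nitrogen, 1 oxygen; one six-membered aromatic ring with 1 hetero atom) in place of a group of 2 heavy atoms (1 carbon, 1 oxygen; no ring), on an aromatic carbon. The change falls on an aromatic carbon, two ring bonds from the ring nitrogen.

The measured steps all exchange one small group on an aromatic carbon and leave the formyl in place. Among the measured compounds shown here, no measured compound lacks the formyl, so these steps bear on the change only indirectly. Even so, given the size of the entering group, a rise in this assay larger than a 3.0-fold higher number from compound 1 to compound 2 (0.48 log units; beyond the scatter) is expected, with its size poorly fixed. The expected change is a 3.0-fold higher number from compound 2 to compound 4 (0.48 log units; beyond the scatter). For compound 4 the estimated value is 200 nM, with an expected range of 30 nM to 1500 nM.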

Compound 4, half-maximal inhibitory concentration: 260 nM
Compound 4: middle estimate off by 1.3-fold (0.11 log units), on the low side, within the range that was stated.
By their numbers in this assay, from the lowest: compound 1; then compounds 3 and 2 (each within the scatter of the next); then compound 4.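

Among the compounds shown here, the earlier compounds varied only a small group on an aromatic carbon, whereas this result is the first reading on the position two ring bonds from the ring nitrogen, where the formyl stands. In this assay the exchange gives a 3.9-fold higher number from compound 2 to compound 4 (0.60 log units; beyond the scatter), so replacing the formyl with a group of 11 heavy atoms that carries a six-membered aromatic ring with 1 hetero atom weakens the compound but leaves compound 4 with a nanomolar number, which shows that this larger group can be accommodated at this position without loss of all activity and that the formyl is not essential on the trifluoromethyl compound. Nothing in the data given accounts for the size of this step or assigns it to any part of the entering group.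

The compounds shown leave open whether the same exchange would have a similar effect with the methoxy of compound 1 or the ethyl of compound 3 in place of the trifluoromethyl. They also leave open how a smaller replacement for the formyl, such as a nitrile, a hydroxymethyl group or a carboxylic acid, would read in this assay, and so whether the size of the entering group matters at all.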